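Trifluoromethyl in Place of Hydrogen on the Aromatic Ring

A few compounds are considered here, and "the series" means these few. Any claim that something is new, unique, unknown or untested is made for them only; others in the source may bear on it.

Of the compounds shown here, three have been measured in a functional assay on MCF7 cells (Homo sapiens) for inhibition, read by sulforhodamine B assay, with a stated time of 48 h; a lower number here means a stronger inhibitor of growth, a higher number a weaker inhibitor of growth. Compound 1 `COc1ccc(/C=C/C2CC(=O)C=CO2)cc1OC` gives 130 uM and compound 3 `O=C1C=CCC(/C=C/c2ccccc2C(F)(F)F)N1` gives 120 uM. Compound 2 `O=C1C=CCC(/C=C/c2ccccc2)N1` gives 607 uM, the highest of the three numbers; both compound 1 and compound 3 sit lower by margins beyond the scatter, with compound 1 the nearer of the two.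

Compound 4 `O=C1C=CCC(/C=C/c2ccc(C(F)(F)F)cc2)N1` has not yet been measured. It differs from compound 2 in one place: trifluoromethyl in place of hydrogen on an aromatic carbon. Among the compounds with values here, the only measured step that bears on this change is the one from compound 2 to compound 3, where the same trifluoromethyl entered in place of hydrogen on an aromatic carbon and gave a 5.1-fold lower number from compound 2 to compound 3 (0.70 log units; beyond the scatter). On that single precedent the account expects a step of comparable size and in the same downward direction, a 4.0-fold lower number from compound 2 to compound 4 (0.61 log units; beyond the scatter), while allowing that one example is a thin basis. Compound 4 is therefore estimated in this assay at 150 uM, within a range from 50 uM to 450 uM.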

Compound 4, concentration for growth inhibition (reported as GI): 150 uM
The estimate for compound 4 equals the measured number at the digits printed; low and high end bracket the measured number.
By their numbers in this assay, from the lowest: compounds 3, 1 and 4 (each within the scatter of the next); then compound 2.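

In this assay, trifluoromethyl in place of hydrogen para to a group of 9 heavy atoms also lowers the number, a 4.0-fold lower number from compound 2 to compound 4 (0.61 log units; beyond the scatter), so the change now holds at a second aromatic carbon of the same ring. Compound 3, with trifluoromethyl on a different aromatic carbon, gives 120 uM and compound 4 gives 150 uM, values within the scatter of each other, so these numbers do not separate the two places. Nothing shown here gives a reason for this step.

The compounds shown leave open whether a nitrile or an amine on this aromatic carbon would lower the number as trifluoromethyl does. They also leave open whether trifluoromethyl would have a similar effect on the core of compound 1.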